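A few compounds are considered here, and "the series" means these few. Any claim that something is new, unique, unknown or untested is made for them only; others in the source may bear on it.

For the measured compounds named here, the three compounds measured so far share one core, carried by compound 1 `O=C/C=C/c1ccccc1OCc1ccccc1Cl`, compound 2 `O=C/C=C/c1ccccc1OCc1cccc(Cl)c1` and compound 3 `O=C/C=C/c1ccccc1OCc1cccc(F)c1`. In a functional assay on cells (Neutrophil, Rattus norvegicus, strain Sprague-Dawley) for inhibition (a lower number here means a stronger inhibitor, a higher number a weaker inhibitor), compound 1 gives 4400 nM, compound 2 gives 5900 nM and compound 3 gives 4500 nM. Compound 2 thereby sits at the top of the three numbers, but its distance to compound 3 and its distance to compound 1 both lie within the scatter, so the three cannot be told apart. Going by the values given here, the one single-point step in hand, a 1.3-fold lower number from compound 2 to compound 3 (0.12 log units; within the scatter), is likewise within the scatter.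

Compound 4 `O=C/C=C/c1ccccc1OCc1ccc(Cl)c(Cl)c1` has not yet been measured. From compound 2 it differs by chloro in place of hydrogen on an aromatic carbon: a chloro enters on an aromatic carbon of the six-membered aromatic ring of carbon only, ortho to a chloro group and para to a large group. Among the compounds with values here, no measured step adds a chloro to this ring; the only measured step swaps chloro for fluoro and is small, and compound 1 and compound 2, which carry chloro at different places, give numbers within the scatter of each other. A step beyond the scatter is therefore not expected, and the expected step is a 1.3-fold lower number from compound 2 to compound 4 (0.12 log units; within the scatter). Compound 4 is expected to give 4500 nM in this assay, with a range from 1500 nM to 14000 nM.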

Compound 4, half-maximal inhibitory concentration: 4300 nM
Beside the measured number, compound 4's estimate is 1.0-fold (0.02 log units) above it; low and high end bracket the measured number.
By their numbers in this assay, from the lowest: compounds 4, 1, 3 and 2 (each within the scatter of the next).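

In this assay, for the compounds shown here, a second chloro entering on this aromatic carbon, ortho to a chloro group and para to a large group, gives a 1.4-fold lower number from compound 2 to compound 4 (0.14 log units; within the scatter), so the added chloro produces no step that can be told from the scatter. Going by these compounds alone, this is the first measured step that adds a heavy atom to the ring instead of exchanging one for another, and like the exchange of chloro for fluoro, a 1.3-fold lower number from compound 2 to compound 3 (0.12 log units; within the scatter), it does not separate the two numbers it joins. Nothing measured here bears on why the number holds through this addition.

The compounds shown leave open whether any group at this place can move the number beyond the scatter, since the ring carries only chloro or fluoro in all four, and a methoxy group, an amine or a carboxylic acid there would be a different test. They also leave open how much the rest of the shared core contributes, as the aldehyde end stays the same throughout and a carboxylic acid in its place would speak to that.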